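The source may report more compounds than this note shows. Statements on the series, on what has been measured and on what is new or still open speak of the compounds shown alone.

Compound 2 `CNc1nc(NCCCN(C)C)c2sc(-c3ccc(C(F)(F)F)cc3)cc2n1` gives 4.1 in a physicochemical assay for lipophilicity, read by HPLC, at pH 7.4; a higher number here means a more lipophilic compound, a lower number a more polar compound. Among the three measured compounds it stands second highest: compound 3 `CNc1nc(NCCCN(C)C)c2sc(-c3ccc(C(F)(F)F)cc3Cl)cc2n1` gives 4.5, the step of a number 0.40 log units higher from compound 2 to compound 3 (beyond the scatter) lying beyond the scatter, while compound 1 `CNc1nc(NCCCN(C)C)c2sc(-c3cccc(C#N)c3)cc2n1` gives 2.9, the lowest of the three. Compound 4 `CNc1nc(NCCCN(C)C)c2sc(-c3ccccc3)cc2n1` differs from compound 2 by hydrogen in place of trifluoromethyl on an aromatic carbon. Going by the values given here, no measured step removes a trifluoromethyl, so the single step from compound 2 to compound 3 shows only that a change on that ring moves this assay by a modest amount. Compound 1, which carries a nitrile where compound 2 carries the trifluoromethyl, sits well lower, and that points downward. The step is expected to be a number 0.80 log units lower from compound 2 to compound 4 (beyond the scatter). Compound 4 is thus estimated at 3.3, within 2.9 to 3.7.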

Compound 4, distribution coefficient: 2.2
Compound 4: the middle estimate sits 1.10 log units above what was measured, and the stated range ends above it.
By their numbers in this assay, from the lowest: compound 4; then compound 1; then compound 2; then compound 3.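

In this assay, the loss of the trifluoromethyl is the largest change seen on this ring so far: a number 1.90 log units lower from compound 2 to compound 4 (beyond the scatter). Compound 4 also falls under the nitrile compound, a number 0.70 log units lower from compound 1 to compound 4 (beyond the scatter), so both of these groups read higher than plain hydrogen in the measured compounds, and the nitrile does not mark the low end of the series. Nothing available here explains the size of these steps. On these data alone, it remains open where an amine or a carboxylic acid on that aromatic carbon would fall, and whether chloro would add the same amount to compound 4 as it does to compound 2.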